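Methylcarbamoyl for aminomethyl on the shared core

The compounds below may be only part of what the source reports. "The series", "measured", "known", "first", "only" and "open" are said of these compounds alone.

The three measured compounds share one core and differ only in the group on the five-membered aromatic ring with one nitrogen and one oxygen. Compound 1 `CCNC(=O)c1noc(-c2cc(C(C)C)c(O)cc2O)c1-c1cc(CN)no1` gives 84 nM in a functional assay on HCT-116 cells (Homo sapiens) for inhibition; on this read-out lower numbers stand for stronger inhibition and higher numbers for weaker inhibition. Compound 2 `CCNC(=O)c1noc(-c2cc(C(C)C)c(O)cc2O)c1-c1cc(CN(C)C)no1` gives 92 nM, and compound 3 `CCNC(=O)c1noc(-c2cc(C(C)C)c(O)cc2O)c1-c1cc(CN2CCCC2)no1` gives 51 nM. Compound 1 stands second highest of the three numbers: its nearest neighbour is compound 2, with a 1.1-fold higher number from compound 1 to compound 2 (0.04 log units; within the scatter), and its furthest is compound 3, with a 1.6-fold lower number from compound 1 to compound 3 (0.22 log units; within the scatter). Between the other two, a 1.8-fold lower number from compound 2 to compound 3 (0.26 log units; within the scatter). All three steps stay within the scatter.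

Compound 4 `CCNC(=O)c1noc(-c2cc(C(C)C)c(O)cc2O)c1-c1cc(C(=O)NC)no1` differs from compound 1 by methylcarbamoyl in place of aminomethyl on an aromatic carbon. Here the aminomethyl is not varied at its nitrogen but replaced outright by a methylcarbamoyl, so no measured step covers this change directly. The three steps show only that exchanging amino for dimethylamino or pyrrolidin-1-yl on the saturated chain carbon leaves the read-out within the scatter; whether the ring position tolerates a methylcarbamoyl is not shown. The expectation is therefore for a step of a 2.0-fold higher number from compound 1 to compound 4 (0.31 log units; beyond the scatter), with wide uncertainty.

Compound 4 is estimated at 170 nM, within 50 nM to 600 nM.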

Compound 4, half-maximal inhibitory concentration: 124 nM
Compound 4: middle estimate off by 1.4-fold (0.14 log units), on the high side; the measured number falls inside the stated range.
By their numbers in this assay, from the lowest: compounds 3, 1, 2 and 4 (each within the scatter of the next, the first and the last beyond it).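

Notes on the group at the aromatic carbon next to the ring nitrogen: in this assay, the change from aminomethyl to methylcarbamoyl gives a 1.5-fold higher number from compound 1 to compound 4 (0.17 log units; within the scatter), and the change from (dimethylamino)methyl gives a 1.3-fold higher number from compound 2 to compound 4 (0.13 log units; within the scatter), so at this position a read-out within the scatter of compound 1 and compound 2 does not depend on an amine nitrogen on a saturated chain carbon. The comparison with the (pyrrolidin-1-yl)methyl group gives a different reading, a 2.4-fold higher number from compound 3 to compound 4 (0.39 log units; beyond the scatter), a modest step and the only one in this set that lies beyond the scatter, so the replacement can be told apart from only one of the three amines. Nothing at hand bears on why the read-out holds against two of these groups and shifts against the third.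

Still open, on these data alone, is whether the carbonyl or the amide hydrogen matters here, which a carboxylic acid, a methyl ester or a dimethylcarbamoyl group at the same carbon would address. Also open, as far as these compounds go, is how a longer chain on the amide nitrogen, such as ethylcarbamoyl or a cyclic pyrrolidine-1-carbonyl group, would compare with methylcarbamoyl.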